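Adding a bromo group to an inactive triazole ester

The compounds below may be only part of what the source reports. "The series", "measured", "known", "first", "only" and "open" are said of these compounds alone.

Measured so far:
compound 1 `COC(=O)c1nc(C)n(-c2ccccc2)n1` — > 100000 nM
compound 2 `COC(=O)c1nc(C)n(-c2ccccc2C(F)(F)F)n1` — 6130 nM

Both compounds were tested in a functional assay on NCI-H226 cells (Homo sapiens) for inhibition, read by MTT assay, with a stated time of 72 h; on this read-out lower numbers stand for stronger inhibition of growth and higher numbers for weaker inhibition of growth. Compound 1 gives > 100000 nM, which is a limit of the assay and not a number. Compound 1 therefore sits at the limit of > 100000 nM in this assay, at which 1 of the 2 values shown sits. Compound 2 carries a trifluoromethyl on the phenyl ring of the shared core and gives 6130 nM. The step of an at least 16-fold lower number from compound 1 to compound 2 (1.21 log units; beyond the scatter) shows that adding a substituent to this ring produced a clear gain.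

Compound 3 `COC(=O)c1nc(C)n(-c2cccc(Br)c2)n1` is not yet measured. It differs from compound 1 by bromo in place of hydrogen on an aromatic carbon. For the measured compounds named here, the only measured step that bears on it is the one from compound 1 to compound 2, which was large; it involved a different group, so it offers only a rough guide for a bromo placed meta to a large group. Compound 3 is expected to show an at least 3.3-fold lower number from compound 1 to compound 3 (0.52 log units; beyond the scatter). The estimate for compound 3 in this assay is 30000 nM, with a range from 5000 nM to 150000 nM.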

Compound 3, concentration for 50% growth inhibition: 7350 nM
Compound 3: the middle estimate sits 4.1-fold (0.61 log units) above what was measured; the measured number falls inside the stated range.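

In this assay the bromo, placed on an aromatic carbon meta to a large group, gives an at least 13-fold lower number from compound 1 to compound 3 (1.13 log units; beyond the scatter) on the phenyl ring of the shared core. The gain seen earlier with trifluoromethyl is therefore not tied to that one group: a different substituent, a single bromine atom, also turns compound 1 into a compound with a measurable value. On these data alone, this step can be read only as a minimum and its true size remains unknown, because compound 1 has no exact number of its own: the limit of > 100000 nM in this assay, at which 1 of the 3 values shown sits.

The compounds shown leave open whether the gain depends on the nature of the group or only on the ring carrying a substituent; a hydroxyl, an amine or a carboxylic acid at the same position would help to separate these two readings. They also leave open how a bromo behaves at the other positions of the ring, and whether the methyl ester of the shared core is needed, which an amide or a carboxylic acid in its place would test.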